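Cytotoxicity at the limit across the biaryl amide series

The source may report more compounds than this note shows. Statements on the series, on what has been measured and on what is new or still open speak of the compounds shown alone.

Compound 1 `CC(C)N(Cc1cccc(OCCCCCC(=O)O)c1)C(=O)c1ccc(-c2cccc(N(C)C)c2)cc1`: in an ADME assay on HepG2 cells (Homo sapiens) for cytotoxicity, read by CellTiter-Glo and resazurin assay, with a stated time of 72 h (a higher number here means that more compound is needed for the effect, a lower number that less compound is needed), compound 1 gives > 26000 nM, a limit of the assay.
Compound 2 `CC(C)N(Cc1cccc(OCCCCCC(=O)O)c1)C(=O)c1ccc(-c2cccc(-c3ccccc3)c2)cc1`: compound 2 gives > 26000 nM, also a limit.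
Compound 3 `CCOC(=O)CCCCCOc1cccc(CN(C(=O)c2ccc(-c3cccc(-c4ccccc4)c3)cc2)C(C)C)c1`: compound 3 gives > 26000 nM, again a limit.

Compound 3 therefore stands only at a limit, as do the other two values shown; (the limit of > 26000 nM in this assay, at which 3 of the 3 values shown sit). The steps a step that the two limits leave unreadable from compound 1 to compound 2 and a step that the two limits leave unreadable from compound 2 to compound 3 are both unreadable. Compound 4 `CCOC(=O)CCCCCOc1cccc(CN(C(=O)c2ccc(-c3cccc(OC)c3)cc2)C(C)C)c1` differs from compound 3 by methoxy in place of phenyl on an aromatic carbon. The first of the measured steps, an exchange on the same aromatic carbon, bears most on this change, but neither gives a readable size, so no step beyond the scatter is expected. Compound 4 is expected to give 35000 nM (range 15000 nM to 100000 nM), most likely again only a limit. The expected step that the limit leaves unreadable from compound 3 to compound 4 is small.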

Compound 4, half-maximal effective concentration: > 21000 nM
Compound 4: a limit, no number; the forecaster's own chance of this, stated with the estimate: 85%; the middle value lies beyond the limit too.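

Compound 3 and compound 4 both sit at limits in this assay, so no step can be read between them. The compounds shown leave open at what concentration any of them acts on these cells, and whether exchanging phenyl for methoxy changes it.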